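This account rests on a few compounds, and the source may have more. Where it says the series, first, only, none or still open, it means among the compounds named here.

Compound 1 `CCCn1c(=O)c2[nH]c(-c3ccc(OC)cc3O)nc2n(CCC)c1=O` gives 4.6 nM in an assay on membranes from brain for antagonist activity at adenosine receptor A1 (Rattus norvegicus); a higher number here means a weaker inhibitor, a lower number a stronger inhibitor.
Compound 2 `CCCn1c(=O)c2nc(-c3ccc(OCC(=O)O)cc3O)[nH]c2n(CCC)c1=O` gives 37 nM in this assay.

Of the two measured compounds, compound 2 has the higher number in this assay; compound 1 sits at 4.6 nM, and the gap between them lies beyond the usual scatter. Compound 3 `CCCn1c(=O)c2nc(-c3ccc(OCC(=O)NCCN)cc3O)[nH]c2n(CCC)c1=O` has not been measured. It differs from compound 2 in one place: (2-aminoethyl)amino in place of hydroxy on a carbonyl carbon. Among the compounds with values here, no pair of measured compounds shows this change, so its effect must be guessed from what the two values show. Compound 1, which lacks the carboxy group, stands well below compound 2, and the amide in compound 3 removes that same carboxy group while adding the (2-aminoethyl)amino chain. The expected step from compound 2 to compound 3, a 3.7-fold lower number from compound 2 to compound 3 (0.57 log units; beyond the scatter), is a moderate fall in the number, beyond the scatter. Compound 3 is expected to give 10 nM in this assay, within a range of 3 nM to 40 nM.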

Compound 3, antagonist equilibrium constant in the adenosine receptor A1 assay: 2.4 nM
For compound 3 the middle estimate is 4.2-fold (0.62 log units) above the measured one; the measured number lies below the stated range.
By their numbers in the adenosine receptor A1 assay, from the lowest: compounds 3 and 1 (each within the scatter of the next); then compound 2.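

In the adenosine receptor A1 assay, (2-aminoethyl)amino in place of hydroxy on a carbonyl carbon gives a 15-fold lower number from compound 2 to compound 3 (1.19 log units; beyond the scatter) and thus a large change beyond the scatter, with compound 2 at 37 nM and compound 3 at 2.4 nM. Within the data shown here, this is the first direct reading at this position, and it shows that the carboxymethoxy group can be extended to ((2-aminoethyl)carbamoyl)methoxy with no loss in this assay. In a physicochemical assay for solubility, in the presence of a further agent that is not named here (on this read-out higher numbers stand for higher solubility and lower numbers for lower solubility), the same change gives a 1.5-fold lower number from compound 2 to compound 3 (0.19 log units; within the scatter) and so leaves the two compounds within the scatter of each other, with compound 2 at 1100000 nM and compound 3 at 710000 nM. Nothing shown here gives a reason for the step in binding.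

The compounds shown leave open whether the step needs the terminal amine or comes with the amide alone. A methyl amide would separate these two readings, and a longer chain ending in an amine would show how far the chain can extend.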